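Fluorine on the pyridine sulfonyl ring: a small step tested

The source may report more compounds than this note shows. Statements on the series, on what has been measured and on what is new or still open speak of the compounds shown alone.

Of the compounds shown here, two of a shared core have been measured so far. Compound 1 `CNCc1cc(-c2cccnc2F)n(S(=O)(=O)c2cccs2)c1` is one of them; in a functional assay on the whole organism (strain Jcl:Sprague-Dawley) for inhibition, with Rattus norvegicus as the target, with stated times of 3 min and 3 h, at a dose of 1 mg/kg by the intravenous route (a lower number here means less inhibition, a higher number more inhibition at the dose given (going by the name of the read-out)), compound 1 gives 96%. Compound 2 `CNCc1cn(S(=O)(=O)c2ccccn2)c(-c2cccnc2F)c1F` is the other, and in this assay compound 2 gives 95%. The two numbers sit within the usual scatter of repeated measurements of each other, so compound 2 stands at the same level as its only companion, near the top of the scale.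

Compound 3 `CNCc1cn(S(=O)(=O)c2ccc(F)cn2)c(-c2cccnc2F)c1F` differs from compound 2 in one place: fluoro in place of hydrogen on an aromatic carbon. For the measured compounds named here, no pair of measured compounds shows a step of a single change, so there is no measured step to lean on here. With both measured numbers already high in this assay, and the change a single fluorine on the pyridin-2-yl ring, no step beyond the scatter is expected in either direction. The step from compound 2 to compound 3 is estimated as a number 1 percentage points lower from compound 2 to compound 3 (within the scatter). For compound 3 the expected value is 94%, within a range from 85% to 99%.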

Compound 3, a percentage reported as inhibition, in the whole organism at one dose (the size of the read-out at that dose, not a potency): 87%
Compound 3: middle estimate off by 7 percentage points, on the high side, within the range that was stated.
By their numbers in this assay, from the lowest: compounds 3, 2 and 1 (each within the scatter of the next).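

For the compounds shown here, compound 3 gives the first single-change step of the set, and it falls on the pyridin-2-yl ring attached through the sulfonyl group. In this assay, replacing hydrogen with fluoro, to give a 5-fluoropyridin-2-yl ring, amounts to a number 8 percentage points lower from compound 2 to compound 3 (within the scatter); the new atom stands two atoms from the ring nitrogen and para to a large group. This position therefore accepts a fluoro group with no change that can be told apart from ordinary repeat-to-repeat variation, although nothing measured here offers an explanation for the number.

The compounds shown leave open whether this position would accept something other than a single fluorine, such as a chloro, methoxy or amino group or a carboxylic acid, and whether a fluoro group would give a similar result elsewhere on the same ring. Since the read-out reflects one dose rather than a potency, they also leave open whether compound 2 and compound 3 would remain within the scatter of each other at a lower dose.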